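Chain-end variation: formyl to acetoxymethyl

The compounds below may be only part of what the source reports. "The series", "measured", "known", "first", "only" and "open" are said of these compounds alone.

All three values below come from a functional assay on Hs-578T cells (Homo sapiens) for antiproliferative activity (a lower number here means a stronger inhibitor of growth, a higher number a weaker inhibitor of growth), and all three are limits of the assay.

- compound 1 `COC(=O)CCCCCCCCCCCCCC/C=C1\CC(CO)(COC(=O)C(C)(C)C)OC1=O` gives > 10 ug/mL (a limit)
- compound 2 `CC(C)(C)C(=O)OCC1(CO)C/C(=C\CCCCCCCCCCCO)C(=O)O1` gives > 10 ug/mL (a limit)
- compound 3 `CC(C)(C)C(=O)OCC1(CO)C/C(=C\CCCCCCCCCCCCCCC=O)C(=O)O1` gives > 10 ug/mL (a limit)

Compound 3 stands only at a limit of > 10 ug/mL (no number places it). The whole set sits at the limit of > 10 ug/mL in this assay, at which 3 of the 3 values shown sit (none of the three separates from the others).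

Compound 4 `CC(=O)OCCCCCCCCCCCCCCC/C=C1\CC(CO)(COC(=O)C(C)(C)C)OC1=O` carries acetoxymethyl in place of formyl on a saturated chain carbon, ten or more bonds along the chain from a double-bonded chain carbon. The same difference, cut further out, reads 3-formylpropyl to 4-acetoxybutyl.

Two measured steps change this same chain end of compound 3: a step that the two limits leave unreadable from compound 1 to compound 3 and a step that the two limits leave unreadable from compound 2 to compound 3 (neither has a readable size). The remaining one, a step that the two limits leave unreadable from compound 1 to compound 2 (also unreadable), adds no size either. No direction can be taken from them, and no step beyond the scatter is expected in this assay on these data.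

The expected step is a step that the limit leaves unreadable from compound 3 to compound 4 (an estimate, with no direction read from the measured steps). A further limit is the likeliest report, an expectation resting only on the limit of > 10 ug/mL in this assay, at which 3 of the 3 values shown sit (the sole ground available). For compound 4 the estimated value is 15 ug/mL (expected range 7 ug/mL to 40 ug/mL).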

Compound 4, concentration for 50% growth inhibition: > 10 ug/mL
Compound 4 gave a limit, no number; the forecaster's own chance of this, stated with the estimate: 85%; the middle value is on the limit's open side.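

Compound 4 gives only a limit in this assay, so its steps to compound 1, compound 2 and compound 3 cannot be read, and the series stays at a single limit: the limit of > 10 ug/mL in this assay, at which 4 of the 4 values shown sit. The compounds shown leave open whether these chain ends differ at all in growth inhibition, and in which direction.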